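Swapping the Arylalkyl Group on the Urea Nitrogen

The source may hold more compounds than are shown below. What is called first, only, known or untested is meant among the compounds shown, and "the series" means these compounds.

Compound 3 `Cc1nc(N)sc1CCCN/C(N)=N/C(=O)NC(C)c1cccs1` stands second highest of the three numbers in an assay on membranes from Sf9 cells for displacement of a labelled ligand from histamine H2 receptor (Homo sapiens), read by scintillation counting, with a stated time of 60 min (a higher number here means a weaker inhibitor, a lower number a stronger inhibitor), giving 63.1 nM. Compound 1 `Cc1nc(N)sc1CCCN/C(N)=N/C(=O)NC1CCCCC1` gives 170 nM, and compound 2 `CCCCCNC(=O)/N=C(\N)NCCCc1sc(N)nc1C` gives 4.47 nM. Among the measured compounds shown here, the step of a 2.7-fold lower number from compound 1 to compound 3 (0.43 log units; beyond the scatter) was modest, while a 14-fold higher number from compound 2 to compound 3 (1.15 log units; beyond the scatter) was large, so the group on the amide-type nitrogen clearly sets the number, with the pentyl chain of compound 2 giving the lowest value so far. Compound 4 `Cc1nc(N)sc1CCCN/C(N)=N/C(=O)NCc1ccco1` differs from compound 3 in one place: (furan-2-yl)methyl in place of 1-(thiophen-2-yl)ethyl on an amide-type nitrogen. For the measured compounds named here, no measured step trades one five-membered aromatic ring for another, so the closest guide is the gap between compound 1 and compound 3, where two groups of similar size gave a modest step. A similarly sized step, in either direction, is expected in this assay, with no strong reason to favour one side. Compound 4 is therefore estimated at 50 nM, within 15 nM to 200 nM, which corresponds to the expected step of a 1.3-fold lower number from compound 3 to compound 4 (0.10 log units; within the scatter).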

Compound 4, inhibition constant: 10.5 nM
Beside the measured number, compound 4's estimate is 4.8-fold (0.68 log units) above it; the whole stated range lies above it.
By their numbers in this assay, from the lowest: compound 2; then compound 4; then compound 3; then compound 1.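

In this assay two groups that each carry one five-membered aromatic ring with one hetero atom prove far from interchangeable on the amide-type nitrogen: (furan-2-yl)methyl in place of 1-(thiophen-2-yl)ethyl gives a 6.0-fold lower number from compound 3 to compound 4 (0.78 log units; beyond the scatter). The same group also gives a 16-fold lower number from compound 1 to compound 4 (1.21 log units; beyond the scatter) and so brings a ring-bearing group much closer to the pentyl chain, which still keeps the lower number, with a 2.3-fold higher number from compound 2 to compound 4 (0.37 log units; beyond the scatter). This swap changes the ring's hetero atom, sulfur to oxygen, and the link, ethyl to methyl, at once, so the step cannot be assigned to either change alone.

No measurement given here explains the size of this step. Still open, on these data alone, are how (thiophen-2-yl)methyl or 1-(furan-2-yl)ethyl would compare, which would separate the two changes, and how benzyl or a longer chain such as hexyl would fare on this nitrogen.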